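The source may hold more compounds than are shown below. What is called first, only, known or untested is meant among the compounds shown, and "the series" means these compounds.

Measured so far:
compound 1, `Nc1ccccc1NC(=O)c1ccc(CSC(=S)N2CCN(c3ccc(Cl)cc3)CC2)cc1`: 51.2%
compound 2, `CC1CCCCN1C(=S)SCc1ccc(C(=O)Nc2ccccc2N)cc1`: 45.5%
compound 3, `Nc1ccccc1NC(=O)c1ccc(CSC(=S)N(Cc2ccccc2)Cc2ccccc2)cc1`: 1%

In a functional assay on HeLa cells (Homo sapiens) for antiproliferative activity, read by CCK-8 assay, with a stated time of 72 h, tested at 2 uM (a higher number here means a stronger effect of the compound at the concentration tested, a lower number a weaker effect), compound 1 gives 51.2%, the highest number of the three. Compound 2 gives 45.5%, which sits within the usual scatter of that number, so the two cannot be told apart. Compound 3 gives 1%, far below and well beyond the scatter. Compound 4, `Nc1ccccc1NC(=O)c1ccc(CSC(=S)N2CCN(C3CCCCC3)CC2)cc1`, is not yet measured. It differs from compound 1 in one place: cyclohexyl in place of 4-chlorophenyl on an amine nitrogen in a ring. Within the data shown here, no measured pair shows this exact change, so the size of the step is open. In this assay a modest fall is expected, possibly still within the scatter, because compound 2 gives 45.5% while compound 3 gives 1%. Compound 4 is therefore expected to give about 40%, between 15% and 62%. The expected step of a number 11.2 percentage points lower from compound 1 to compound 4 (beyond the scatter) is downward but small.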

Compound 4, a percentage reported as inhibition, at one concentration (the size of the read-out at that concentration, not a potency): 30.6%
The estimate for compound 4 lay 9.4 percentage points above the measured number, and the stated range covers the measured number.
By their numbers in this assay, from the lowest: compound 3; then compound 4; then compounds 2 and 1 (each within the scatter of the next).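

In this assay, cyclohexyl in place of 4-chlorophenyl on this amine nitrogen in a ring gives a number 20.6 percentage points lower from compound 1 to compound 4 (beyond the scatter). At this position, then, the two six-membered rings are not interchangeable, although the compound with the non-aromatic ring still retains a measurable effect. No measurement at hand gives a reason for this step. The compounds shown leave open whether the difference depends on the chlorine or on the aromatic ring itself. A plain phenyl group at this position would help separate these two possibilities, and a small methyl group would show whether any ring is needed there.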